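The compounds below may be only part of what the source reports. "The series", "measured", "known", "first", "only" and "open" are said of these compounds alone.

Compound 1 `CCCC(CCC(=O)O)Cc1ccc(OCc2ccc3ccccc3n2)cc1` carries a carboxy group on its side chain, and in a functional assay (lung) for inhibition, with Cavia porcellus as the target (on this read-out higher numbers stand for weaker inhibition and lower numbers for stronger inhibition), compound 1 gives 30 nM. Compound 2 `CCCC(CCc1nnn[nH]1)Cc1ccc(OCc2ccc3ccccc3n2)cc1` differs from it by 1H-tetrazol-5-yl in place of carboxy on a saturated chain carbon, four bonds along the chain from an aromatic carbon; in this assay compound 2 gives 32 nM, a step of a 1.1-fold higher number from compound 1 to compound 2 (0.03 log units; within the scatter). Compound 3 `O=C(O)CC1(CCc2ccc(OCc3ccc4ccccc4n3)cc2)CCCC1` rests on another core; the difference between the cores of compound 1 and compound 3 is not broken down here. In this assay compound 3 gives 60 nM.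

Compound 4 `c1ccc2nc(COc3ccc(CCC4(Cc5nnn[nH]5)CCCC4)cc3)ccc2c1` is not yet measured. It differs from compound 3 by 1H-tetrazol-5-yl in place of carboxy on a saturated chain carbon bound to a saturated ring carbon. This is the same kind of change as that from compound 1 to compound 2, though the place is not identical: there the group sat on a saturated chain carbon, four bonds along the chain from an aromatic carbon, here on a saturated chain carbon bound to a saturated ring carbon. Because the earlier step was a 1.1-fold higher number from compound 1 to compound 2 (0.03 log units; within the scatter), the expected step in this assay is a 1.1-fold higher number from compound 3 to compound 4 (0.03 log units; within the scatter). Compound 4 is estimated at 65 nM, with a likely range from 30 nM to 140 nM.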

Compound 4, half-maximal inhibitory concentration: 37 nM
Compound 4: middle estimate off by 1.8-fold (0.24 log units), on the high side, within the range that was stated.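

In this assay, 1H-tetrazol-5-yl in place of carboxy on the second core gives a 1.6-fold lower number from compound 3 to compound 4 (0.21 log units; within the scatter). Set beside the earlier step, the change reads the same on both cores: the same change on two cores in this assay, a 1.1-fold higher number (0.03 log units; within the scatter) from compound 1 to compound 2 and a 1.6-fold lower number (0.21 log units; within the scatter) from compound 3 to compound 4, 1.7-fold (0.24 log units) apart, within the scatter of two such steps. Within this assay the swap therefore carries between these two cores with no resolved shift, but two pairs give no rule for other cores, the place of the group is not identical in the two pairs, and steps this small show neither a gain nor a loss.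

Open, going by these compounds, is whether an acylsulfonamide or a hydroxamic acid in the same place would read alike. Also open, on these data alone, is how either group behaves on a longer chain.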